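The source may hold more compounds than are shown below. What is called first, only, known or untested is meant among the compounds shown, and "the series" means these compounds.

Within the data shown here, compound 2 `CC(C(=O)NCc1ccc(C(F)(F)F)nc1N1CCC(Cc2ccc(F)c(F)c2)CC1)c1ccc(NS(C)(=O)=O)c(F)c1` gives 30 nM in a functional assay on CHO-K1 cells for antagonist activity at transient receptor potential cation channel subfamily V member 1 (Homo sapiens), read by FLIPR (on this read-out lower numbers stand for stronger inhibition and higher numbers for weaker inhibition), the lower of the two numbers so far obtained in this assay. Compound 1 `CC1CCC(Nc2nc(C(F)(F)F)ccc2CNC(=O)C(C)c2ccc(NS(C)(=O)=O)c(F)c2)CC1` gives 1130 nM in this assay, and the gap between the two compounds lies well beyond the scatter of repeated measurements. Compound 3 `COC1CCN(c2nc(C(F)(F)F)ccc2CNC(=O)C(C)c2ccc(NS(C)(=O)=O)c(F)c2)CC1` has not yet been measured. It differs from compound 2 in one place: methoxy in place of 3,4-difluorobenzyl on a saturated ring carbon. Among the measured compounds shown here, no pair of measured compounds shows this change, so there is no measured step to set its size against; the comparison of compound 1 with compound 2 involves a different ring and substituent and shows only what the two values are. The change removes a large aromatic group and puts a small one in its place, and on this basis the expected step is a move toward a weaker number, of a size that is estimated to go beyond the scatter, namely a 20-fold higher number from compound 2 to compound 3 (1.30 log units; beyond the scatter). For compound 3 the estimate in this assay is 600 nM, with a range from 150 nM to 3000 nM.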

Compound 3, half-maximal inhibitory concentration: 280 nM
Estimate against measurement, compound 3: 2.1-fold (0.33 log units) above, within the range that was stated.
By their numbers in this assay, from the lowest: compound 2; then compound 3; then compound 1.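

In this assay, among these compounds, methoxy in place of 3,4-difluorobenzyl on the saturated ring carbon gives a 9.3-fold higher number from compound 2 to compound 3 (0.97 log units; beyond the scatter), which is the first measured size for this change: the step lies beyond the scatter, yet compound 3 still gives a measurable inhibition number of 280 nM without the aromatic ring of the departing group. The same methoxy-bearing compound also sets a measured step on the aromatic carbon of the core, where 4-methoxypiperidin-1-yl in place of (4-methylcyclohexyl)amino gives a 4.0-fold lower number from compound 1 to compound 3 (0.61 log units; beyond the scatter), again beyond the scatter. No measurement available here explains either step.

Because this exchange replaces a large group with a small one and alters several features together, the compounds shown cannot separate the loss of the two fluorines, the loss of the aromatic ring and the arrival of the oxygen. A plain benzyl, a 4-fluorobenzyl, a hydroxyl or a longer chain such as benzyloxy on the same ring carbon would each be needed to show which of these parts carries the difference between compound 2 and compound 3.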